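The source may report more compounds than this note shows. Statements on the series, on what has been measured and on what is new or still open speak of the compounds shown alone.

Measured compounds, all in a functional assay on RKE cells for antagonist activity at Vasoactive intestinal polypeptide receptor 1 (Rattus norvegicus), read by HTRF and cAMP accumulation, with stated times of 10 min and 30 min; a higher number here means a weaker inhibitor, a lower number a stronger inhibitor:
compound 1 `CC(C)c1cc(C(C)(C)C)cc(-c2ccccc2-c2ccccc2)c1CO`: 3200 nM
compound 2 `CC(C)c1cc(C(C)(C)C)cc(-c2ccc(-c3ccccc3)cc2)c1CO`: 680 nM
compound 3 `CC(C)C(=O)Nc1sc2c(c1C#N)CCCC2`: 3400 nM

Compound 3 gives the highest of the three numbers. Compound 1 sits nearest, with a number lower by a margin that lies within the usual scatter of this assay, so the two cannot be ordered against each other. Compound 2 lies furthest, its number lower than that of compound 3 by a margin beyond the scatter. Among the measured compounds shown here, compounds 1 and 2 share one core, compound 3 has another; no single-point step between measured compounds is available, so nothing connects the two cores beyond the bare numbers.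

The next compound, compound 4 `N#Cc1c(NC(=O)C2CCCC2)sc2c1CCCC2`, keeps the core of compound 3 and differs in one place: cyclopentyl in place of isopropyl on a carbonyl carbon. The amide and the nitrile are untouched. For the measured compounds named here, no measured pair in this set exchanges these two groups, so no size can be read off the data. The expectation is a step of modest size at most, with a lower number somewhat more likely than a higher one, and a result within the scatter of compound 3 remaining possible. Compound 4 is estimated at 2500 nM (range 900 nM to 7000 nM). The expected step is a 1.4-fold lower number from compound 3 to compound 4 (0.13 log units; within the scatter).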

Compound 4, half-maximal inhibitory concentration: 470 nM
Compound 4: middle estimate off by 5.3-fold (0.73 log units), on the high side; measured number below the stated range.
By their numbers in this assay, from the lowest: compounds 4 and 2 (each within the scatter of the next); then compounds 1 and 3 (each within the scatter of the next).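

In this assay, among the compounds shown here, cyclopentyl in place of isopropyl on a carbonyl carbon gives a 7.2-fold lower number from compound 3 to compound 4 (0.86 log units; beyond the scatter) and provides the first single-change comparison in the set. The number at this place on the core of compound 3 therefore depends on the group carried there: with the amide and the nitrile unchanged, the 5 heavy atoms and the ring of cyclopentyl go with a lower number than the 3 heavy atoms of isopropyl. No measured information bears on the origin of this step.

The compounds shown leave open whether the ring itself or the larger carbon count goes with the step, a question that an open pentyl chain or a cyclobutyl group on the same carbonyl carbon would address. Also open, on these data alone, is how far this place tolerates other groups, such as cyclohexyl, phenyl or a ring carrying an amine, and whether the step holds when the nitrile gives way to a carboxylic acid.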